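Swapping anilino for benzyl on a quinolinone hydrazone

A few compounds are considered here, and "the series" means these few. Any claim that something is new, unique, unknown or untested is made for them only; others in the source may bear on it.

Measured compounds:
compound 1, `Cc1ccc2[nH]c(=O)c(/C=N/Nc3ccccc3)cc2c1`, 1470000 nM
compound 2, `N/N=C/c1cc2ccccc2[nH]c1=O`, 365000 nM
compound 3, `NS(=O)(=O)c1ccc(/N=C/c2cc3ccccc3[nH]c2=O)cc1`, 266000 nM

In a functional assay, read by spectrophotometry, with a stated time of 1 h (on this read-out lower numbers stand for stronger inhibition and higher numbers for weaker inhibition), compound 1 gives 1470000 nM, the highest number of the three measured compounds. Compound 2 sits nearest, with 365000 nM, a gap beyond the scatter, and compound 3 lies furthest away, with 266000 nM, also beyond the scatter. Compound 1 is therefore the weakest inhibitor of the three in this assay.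

Compound 4, `Cc1ccc2[nH]c(=O)c(/C=N/Cc3ccccc3)cc2c1`, differs from compound 1 in one place: benzyl in place of anilino on a double-bonded nitrogen. Within the data shown here, no step between two measured compounds matches this change, so nothing measured shows how it plays out. Among the measured compounds shown here, with only three weak compounds in hand, and all of them far apart in structure, the account expects at most a modest step in this assay, most likely toward a lower number, though a step within the scatter is also possible.

On that basis compound 4 is estimated at 800000 nM, within a range of 200000 nM to 3000000 nM, which corresponds to an expected step of a 1.8-fold lower number from compound 1 to compound 4 (0.26 log units; within the scatter).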

Compound 4, half-maximal inhibitory concentration: 6920000 nM
Beside the measured number, compound 4's estimate is 8.7-fold (0.94 log units) below it; measured number above the stated range.
By their numbers in this assay, from the lowest: compounds 3 and 2 (each within the scatter of the next); then compound 1; then compound 4.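

In this assay, among these compounds, benzyl in place of anilino on a double-bonded nitrogen gives a 4.7-fold higher number from compound 1 to compound 4 (0.67 log units; beyond the scatter) and so provides the first matched reading at this place, which the earlier compounds could not offer. On the core of compound 1, this change therefore weakens inhibition, so this place does not accept the two groups alike even though they have the same number of heavy atoms and each carries one carbon-only aromatic ring. The groups differ in their counts, with anilino carrying a hydrogen-bond donor and acceptor and benzyl carrying neither, but no measurement here accounts for the change in the number.

From the compounds shown here alone, whether a phenethyl group, a longer chain or a plain methyl at this place would give a lower or a higher number remains open. Going by these compounds, it is also open whether the same change would give a step of similar size on a core without the methyl group of compound 1.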